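A few compounds are considered here, and "the series" means these few. Any claim that something is new, unique, unknown or untested is made for them only; others in the source may bear on it.

In a functional assay on aorta (Rattus norvegicus) for inhibition (on this read-out higher numbers stand for an effect only at larger amounts of compound and lower numbers for an effect already at smaller amounts), three compounds sharing a core have been measured so far. Compound 1 (`CC(C)NC1=NS(=O)(=O)c2cccc(Cl)c2N1`) reaches only a limit of the assay, > 300000 nM. Compound 2 (`CC(C)NC1=NS(=O)(=O)c2ccc(Cl)cc2N1`) gives a number, 53400 nM. Compound 3 (`CCCNC1=NS(=O)(=O)c2cc(Cl)ccc2N1`) gives 55500 nM, which lies within the scatter of the value for compound 2, so the two stand level, and neither can be ranked over the other.

The next compound, compound 4 (`O=S1(=O)N=C(NC2CC2)Nc2ccc(Cl)cc21`), has not yet been measured. Set against compound 3, its change is cyclopropyl in place of propyl on an amine nitrogen. In words, it has cyclopropyl in place of propyl on an amine nitrogen, so the count of heavy atoms in the group stays the same while a ring enters.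

Within the data shown here, no measured pair isolates this change, so the expectation has to start from compound 3 at 55500 nM. Compound 2 at 53400 nM also carries a different group on that nitrogen, and it reads alike. In this assay, no step beyond the scatter is expected, and the estimated move is a 1.2-fold lower number from compound 3 to compound 4 (0.09 log units; within the scatter). The expected value for compound 4 is 45000 nM, with an estimated range from 15000 nM to 130000 nM.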

Compound 4, half-maximal effective concentration: 191000 nM
Estimate against measurement, compound 4: 4.2-fold (0.63 log units) below, outside the stated range (above it).
By their numbers in this assay, from the lowest: compounds 2 and 3 (each within the scatter of the next); then compound 4. At a limit, above all of these: compound 1.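

In this assay the group on the amine nitrogen now proves to matter on its own: with the rest of the compound held the same, cyclopropyl in place of propyl gives a 3.4-fold higher number from compound 3 to compound 4 (0.54 log units; beyond the scatter) and so a modest step toward needing larger amounts. The count of heavy atoms stays the same across this change, so that count alone does not set the number here, and the three-membered ring is what separates the two compounds. Compound 4 still gives a number, but it moves toward the top of the range that the read-out can report: the limit of > 300000 nM in this assay, at which 1 of the 4 values shown sits.

A single pair leaves open whether the higher number follows from the ring as such or from the loss of the open propyl chain, and whether the step would hold with the chlorine elsewhere on the shared core. A cyclobutyl group, a cyclopropylmethyl group or a shorter ethyl chain on the same nitrogen would help to tell these readings apart, and none of them is among the compounds shown.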